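The source may hold more compounds than are shown below. What is called first, only, known or untested is meant among the compounds shown, and "the series" means these compounds.

Measured so far:
- compound 1 `O=C1/C(=C/c2cccnc2)CN(S(=O)(=O)c2ccccc2)C/C1=C\c1ccccc1F`: 8210 nM
- compound 2 `O=C1/C(=C/c2cccnc2)CN(S(=O)(=O)c2ccccc2)C/C1=C\c1ccccc1C(F)(F)F`: 5370 nM

In a functional assay on HepG2 cells (Homo sapiens) for cytotoxicity, read by MTT assay, with a stated time of 24 h (a lower number here means a stronger inhibitor, a higher number a weaker inhibitor), compound 2 stands at 5370 nM, within the scatter of compound 1, so the two numbers cannot be told apart and compound 2 holds no clear place in the pair.

The next compound, compound 3 `N#Cc1ccc(S(=O)(=O)N2C/C(=C\c3cccnc3)C(=O)/C(=C/c3ccccc3C(F)(F)F)C2)cc1`, keeps everything in compound 2 except the phenylsulfonyl group, which becomes (4-cyanophenyl)sulfonyl: cyano in place of hydrogen on an aromatic carbon, para to a large group (cyano in place of hydrogen on an aromatic carbon).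

Within the data shown here, only one measured step is available, a 1.5-fold lower number from compound 1 to compound 2 (0.18 log units; within the scatter). It is a change of trifluoromethyl in place of fluoro, lies within the scatter and leaves the phenylsulfonyl group untouched. Among the measured compounds shown here, it therefore bears on the new change only indirectly, and no measured compound varies the phenylsulfonyl group. The data thus give no direction, and no step beyond the scatter is expected in this assay, although the uncertainty is wide.

The expected change is a 1.1-fold lower number from compound 2 to compound 3 (0.03 log units; within the scatter).

For compound 3 the estimated value is 5000 nM, with an expected range of 2000 nM to 12500 nM.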

Compound 3, half-maximal inhibitory concentration: 5060 nM
Estimate against measurement, compound 3: 1.0-fold (0.01 log units) below; the range from low to high includes it.
By their numbers in this assay, from the lowest: compounds 3, 2 and 1 (each within the scatter of the next).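

In this assay, the change from phenylsulfonyl to (4-cyanophenyl)sulfonyl gives a 1.1-fold lower number from compound 2 to compound 3 (0.03 log units; within the scatter). Among these compounds, the earlier pair varied only the fluoro and trifluoromethyl site, whereas this step is the first look at the phenyl ring on the sulfonyl group, and cyano in place of hydrogen on this aromatic carbon, para to a large group, produces no difference that can be told from the scatter, so at this position the series so far shows no sign that the number responds to the substitution. No measured evidence accompanies this result that could account for it.

The compounds shown contain only one substituent at this position, so a single cyano group leaves open whether a carboxylic acid, an aminomethyl group or a longer alkyl chain at the same place would move the number beyond the scatter. On these data alone, it also remains open whether the same cyano change would read the same way on the fluoro-bearing compound 1, or whether any change on the shared core can take this series clearly away from its present range in this assay.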